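Adding a Nitro Group to the Benzyl of Compound 2

A few compounds are considered here, and "the series" means these few. Any claim that something is new, unique, unknown or untested is made for them only; others in the source may bear on it.

Measured so far in an assay on isolated protein with dual specificity calcium/calmodulin-dependent 3',5'-cyclic nucleotide phosphodiesterase 1B (Bos taurus) as the target, tested at 100 uM; a lower number here means less inhibition, a higher number more inhibition at the concentration tested (going by the name of the read-out):
compound 1, `CC(C)Cn1c(N)nc2c1c(=O)n(CC1CC1)c(=O)n2CC1CC1`, gives 12%
compound 2, `Nc1nc2c(c(=O)n(CC3CC3)c(=O)n2CC2CC2)n1Cc1ccccc1`, gives 27%

Among the compounds with values here, compound 2 stands highest of the two numbers in this assay; its nearest neighbour is compound 1, and the one measured step, a number 15 percentage points higher from compound 1 to compound 2 (beyond the scatter), lies beyond the scatter. Within the data shown here, that step is phenyl in place of isopropyl on a saturated chain carbon bound to an aromatic nitrogen, and it is the only step the set offers.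

Compound 3, `Nc1nc2c(c(=O)n(CC3CC3)c(=O)n2CC2CC2)n1Cc1ccc([N+](=O)[O-])cc1`, is not yet measured. Against compound 2 the difference is nitro in place of hydrogen on an aromatic carbon. Among the measured compounds shown here, no measured step touches a substituent on the phenyl ring itself; the one known step concerns the presence of the ring, not what sits on it, so it bears on the present change only loosely. Without a closer precedent, the account expects for compound 3 a step within the scatter, a number 3 percentage points higher from compound 2 to compound 3 (within the scatter), in this assay. The estimate for compound 3 is 30%, with a range from 10% to 55%.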

Compound 3, a percentage reported as inhibition, at one concentration (the size of the read-out at that concentration, not a potency): 30%
Compound 3: the middle estimate sits on the measured number at the digits printed, within the range that was stated.
By their numbers in this assay, from the lowest: compound 1; then compounds 2 and 3 (each within the scatter of the next).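

Placing a nitro group on the phenyl ring, para to a large group, gives a number 3 percentage points higher from compound 2 to compound 3 (within the scatter) in this assay, so this first change on the ring itself leaves a reading that cannot be told apart from that of the plain benzyl compound. Adding these 3 heavy atoms at this position therefore costs nothing that this read-out can detect, and it adds nothing that it can detect either. The advantage of an aromatic ring over the isopropyl end of the chain also survives the substitution, with a number 18 percentage points higher from compound 1 to compound 3 (beyond the scatter), so the earlier step from isopropyl to phenyl is not confined to the unsubstituted ring. Nothing available bears on why the nitro group leaves the reading where it stands.

Going by these compounds, whether this silence holds for the ring as a whole stays open, since a single group at a single ring position says nothing about an amine, a carboxylic acid or a methoxy group there, or about nitro on another ring carbon. Readings at one concentration also leave open whether compounds that sit this close in this assay would still match in a true potency measurement.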